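Swapping the Amide Aryl Group: Methoxyphenyl to Nitrophenyl

The source may report more compounds than this note shows. Statements on the series, on what has been measured and on what is new or still open speak of the compounds shown alone.

Measured compounds:
Compound 1, `COc1cccc(C(=O)Nc2ccc(Cl)cc2CN2C(=O)c3ccccc3C2=O)c1`: 1500 nM
Compound 2, `Cc1ccc2c(c1C)C(=O)N(Cc1cc(Br)ccc1NC(=O)c1ccccn1)C2=O`: > 100000 nM
Compound 3, `COc1ccc(NC(=O)c2ccccn2)c(CN2C(=O)c3ccccc3C2=O)c1`: 1400 nM

All three were tested in an assay on CHO cells for positive allosteric modulation of metabotropic glutamate receptor 5 (Homo sapiens), read by FLIPR; a higher number here means that more compound is needed for the effect, a lower number that less compound is needed. Compound 1 gives 1500 nM, the higher of the two numbers actually measured. Its nearest neighbour is compound 3 at 1400 nM, and the gap between them lies within the usual scatter, so the two cannot be told apart. Compound 2 reached only (the limit of > 100000 nM in this assay, at which 1 of the 3 values shown sits), which is a limit of the assay rather than a number.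

The step of interest leads from compound 1 to compound 4, `O=C(Nc1ccc(Cl)cc1CN1C(=O)c2ccccc2C1=O)c1ccccc1[N+](=O)[O-]`, which has not yet been measured. The change is 2-nitrophenyl in place of 3-methoxyphenyl on a carbonyl carbon. Among the compounds with values here, no directly comparable pair among the measured compounds shows the effect of such a swap, so the direction of the step is open. Compound 4 is expected to land near 3000 nM, with a plausible range from 600 nM to 20000 nM, meaning an estimated step of a 2.0-fold higher number from compound 1 to compound 4 (0.30 log units; within the scatter) that may not exceed the scatter.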

Compound 4, half-maximal effective concentration: 5700 nM
Compound 4: middle estimate off by 1.9-fold (0.28 log units), on the low side; the range from low to high includes it.
By their numbers in this assay, from the lowest: compounds 3 and 1 (each within the scatter of the next); then compound 4. At a limit, above all of these: compound 2.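

Within the data shown here, this gives the first reading of a change in one place. The earlier compounds shown here offered no such pair. On this carbonyl carbon the aryl group matters: in this assay, 2-nitrophenyl in place of 3-methoxyphenyl gives a 3.8-fold higher number from compound 1 to compound 4 (0.58 log units; beyond the scatter), a modest loss that still leaves compound 4 with a true measured number rather than an assay limit. Nothing measured here explains why the number rises.

The swap changes both the group and its place on the ring, so the compounds shown cannot say which of the two drives the rise. Also open, on these data alone, is how this carbonyl carbon would respond to an unsubstituted phenyl ring, or to a ring bearing an amine or a carboxylic acid.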